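The source may hold more compounds than are shown below. What is called first, only, known or untested is meant among the compounds shown, and "the series" means these compounds.

In an assay on isolated protein for inhibition of aldehyde dehydrogenase 1A1 (Homo sapiens), read by spectrophotometry, tested at 10 uM (a higher number here means more inhibition at the concentration tested (going by the name of the read-out), a lower number less inhibition), three compounds have been measured:

compound 1 `CC(C)=CCn1c(CN2CCN(C(=O)C3CC3)CC2)nc2ccccc21` gives 74.3%
compound 3 `O=C(C1CC1)N1CCN(Cc2nc3ccccc3n2Cc2ccc(Cl)cc2)CC1` gives 56.6%
compound 2 `Cc1cccc(Cn2c(CN3CCN(C(=O)c4ccc(C(F)(F)F)cc4)CC3)nc3ccccc32)c1` gives 22.9%

Compound 2 stands lowest of the three, with compound 3 nearest and compound 1 furthest from it, both gaps beyond the scatter. Compound 4 `COc1ccc(C(=O)N2CCN(Cc3nc4ccccc4n3Cc3cccc(C)c3)CC2)cc1` differs from compound 2 in a single place: methoxy in place of trifluoromethyl on an aromatic carbon. Among the compounds with values here, the only measured step that changes one group, a number 17.7 percentage points lower from compound 1 to compound 3 (beyond the scatter), sits on the saturated chain carbon bound to the aromatic nitrogen, not on the six-membered aromatic ring of carbon only that carries the carbonyl, so no measured step speaks directly to the exchange of trifluoromethyl for methoxy. Compounds 1 and 3 carry a cyclopropyl carbonyl in place of the whole aryl carbonyl of compound 2, and both give higher numbers than compound 2, but that is a different and larger change. Within the data shown here, with no direct precedent, the expectation for compound 4 is a step close to nothing beyond the scatter in this assay, a number 5.1 percentage points higher from compound 2 to compound 4 (within the scatter), with wide uncertainty. Compound 4 is therefore estimated at 28%, expected to fall between 8% and 55%.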

Compound 4, a percentage reported as inhibition, at one concentration (the size of the read-out at that concentration, not a potency): 55.5%
Estimate against measurement, compound 4: 27.5 percentage points below, and the stated range ends below it.
By their numbers in this assay, from the lowest: compound 2; then compounds 4 and 3 (each within the scatter of the next); then compound 1.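

In this assay, the substituent on the aromatic ring that carries the carbonyl matters: with the rest of the molecule unchanged, methoxy in place of trifluoromethyl gives a number 32.6 percentage points higher from compound 2 to compound 4 (beyond the scatter). Within the data shown here, this is the first measured step at this position, para to a large group, and it shows that exchanging one small group here is enough to change the inhibition well beyond the scatter. Nothing measured here explains why this exchange has such an effect.

On these data alone, only these two groups have been compared at this position, so it remains open whether a hydrogen, a chlorine or a dimethylamino group would give a number nearer that of compound 2 or compound 4. As far as these compounds go, it is also open whether the same exchange would give a similar step with the 2-methylprop-1-en-1-yl group of compound 1 on the saturated chain carbon.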